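A few compounds are considered here, and "the series" means these few. Any claim that something is new, unique, unknown or untested is made for them only; others in the source may bear on it.

In a functional assay on HCT-116 cells (Homo sapiens) for antiproliferative activity, read by CCK-8 assay, with a stated time of 72 h, tested at 8 uM (on this read-out lower numbers stand for a weaker effect and higher numbers for a stronger effect at the one concentration tested), compound 1 `Nc1ccccc1NC(=O)/C=C/c1ccc(Cn2cnc3c(Nc4ccccc4)nc(Cl)nc32)cc1` gives 30.9%, compound 2 `CCCCn1cnc2c(Nc3ccccc3)nc(NCOCc3ccc(/C=C/C(=O)Nc4ccccc4N)cc3)nc21` gives 51.9%, and compound 3 `Nc1ccccc1NC(=O)c1ccc(Cn2cnc3c(Nc4ccccc4)nc(Cl)nc32)cc1` gives 83.5%, the highest of the three numbers and beyond the scatter from both others. For the measured compounds named here, the only single-place step on record, a number 52.6 percentage points higher from compound 1 to compound 3 (beyond the scatter), concerns the exchange of 2-((2-aminophenyl)carbamoyl)ethenyl for (2-aminophenyl)carbamoyl and not the anilino group. Going by the values given here, compound 4 `Cc1ccc(Nc2nc(Cl)nc3c2ncn3Cc2ccc(C(=O)Nc3ccccc3N)cc2)cc1` differs from compound 3 by methyl in place of hydrogen on an aromatic carbon; no measured pair shows this change, and compound 2 differs from compound 3 in several places at once, so its number does not bear on it. With nothing to set a direction, the step of a number 5.5 percentage points lower from compound 3 to compound 4 (within the scatter) is expected to stay within the scatter. Compound 4 is therefore estimated at 78%, with a range from 58% to 92%.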

Compound 4, a percentage reported as inhibition, at one concentration (the size of the read-out at that concentration, not a potency): 81.5%
The estimate for compound 4 lay 3.5 percentage points below the measured number; measured number inside the range.
By their numbers in this assay, from the lowest: compound 1; then compound 2; then compounds 4 and 3 (each within the scatter of the next).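

Anilino to (4-methylphenyl)amino is the first change at this ring in the series, and in this assay it gives a number 2 percentage points lower from compound 3 to compound 4 (within the scatter). This single pair shows that methyl on this aromatic carbon, para to a large group, leaves the number within the scatter while the high level seen with compound 3 holds. No available evidence bears on this result.

As far as these compounds go, whether a methoxy group, a chlorine atom, an amine or a longer alkyl chain at this place would do the same remains open. So does whether methyl elsewhere on this ring would.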